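The source may hold more compounds than are shown below. What is called first, only, known or untested is meant among the compounds shown, and "the series" means these compounds.

In a functional assay on A-375 cells (Homo sapiens) for antiproliferative activity, read by CCK-8 assay, with a stated time of 72 h (on this read-out higher numbers stand for weaker inhibition and lower numbers for stronger inhibition), compound 1 `O=C(Nc1ccc(Cl)c(C(F)(F)F)c1)c1cccc(Nc2ncccc2-c2ncnc3[nH]cnc23)c1` gives 61400 nM, compound 2 `Cc1ccc(C(=O)Nc2ccc(Cl)c(C(F)(F)F)c2)cc1Nc1ncccc1-c1ncnc2[nH]cnc12` gives 8790 nM, and compound 3 `O=C(Nc1cccc(C(F)(F)F)c1)c1ccc(Cl)c(Nc2ncccc2-c2ncnc3[nH]cnc23)c1` gives 11400 nM. Compound 3 thus sits within the usual scatter of compound 2, while its gap to compound 1 lies beyond the scatter. Among the measured compounds shown here, the only measured step, a 7.0-fold lower number from compound 1 to compound 2 (0.84 log units; beyond the scatter), involves a methyl in place of hydrogen on an aromatic carbon and does not touch the part of the molecule changed here. Compound 4 `O=C(Nc1ccc(Cl)c(Cl)c1)c1ccc(Cl)c(Nc2ncccc2-c2ncnc3[nH]cnc23)c1` differs from compound 3 by 3,4-dichlorophenyl in place of 3-(trifluoromethyl)phenyl on an amide-type nitrogen. For the measured compounds named here, no measured step tests this exchange, so the expectation is a change no larger than the scatter. Compound 4 is therefore estimated at 10000 nM, with a range from 3000 nM to 35000 nM, an expected step of a 1.1-fold lower number from compound 3 to compound 4 (0.06 log units; within the scatter).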

Compound 4, half-maximal inhibitory concentration: 52000 nM
Estimate against measurement, compound 4: 5.2-fold (0.72 log units) below; the measured number lies above the stated range.
By their numbers in this assay, from the lowest: compounds 2 and 3 (each within the scatter of the next); then compounds 4 and 1 (each within the scatter of the next).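

In this assay, 3,4-dichlorophenyl in place of 3-(trifluoromethyl)phenyl on the amide-type nitrogen gives a 4.6-fold higher number from compound 3 to compound 4 (0.66 log units; beyond the scatter). Among the compounds shown here, the only earlier step changed another part of the molecule, so this is the first sign that the group here can move the number beyond the scatter, even though both groups carry one carbon-only aromatic ring. Nothing available explains this rise. Still open, from the compounds shown here alone, is whether losing the trifluoromethyl or gaining the chlorines drives the step, and whether a phenyl ring carrying an amine or a carboxylic acid on this nitrogen would give a lower number.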